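A few compounds are considered here, and "the series" means these few. Any claim that something is new, unique, unknown or untested is made for them only; others in the source may bear on it.

Within the data shown here, the three compounds measured so far share a core that differs only in the group attached through the carbonyl. In an assay on NIH3T3 cells with Urotensin-2 receptor (Homo sapiens) as the target (a higher number here means a larger maximal response, a lower number a smaller maximal response), compound 1 `Cc1c(Cl)cccc1C(=O)NC(CCN(C)C)c1ccc(Cl)cc1` gives 142%, compound 2 `Cc1cccc(Cl)c1C(=O)NC(CCN(C)C)c1ccc(Cl)cc1` gives 105%, and compound 3 `COc1ccc(NC(=O)NC(CCN(C)C)c2ccc(Cl)cc2)cc1` gives 195%. Compound 3 therefore stands highest of the three in this assay, with compound 1 nearest below it and compound 2 furthest below it, both gaps lying beyond the scatter.

Compound 4 `CN(C)CCC(NC(=O)NCc1ccccc1)c1ccc(Cl)cc1` has not yet been measured in this assay. It differs from compound 3 in a single place: benzyl in place of 4-methoxyphenyl on an amide-type nitrogen.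

Among the measured compounds shown here, only one measured step exists in the set, a number 37 percentage points lower from compound 1 to compound 2 (beyond the scatter). It concerns a rearrangement of substituents on the ring attached to the carbonyl carbon, not the amide-type nitrogen changed here, so it bears on the present step only indirectly; it does show that a modest structural exchange in this series moved the maximal response by a large margin. For the measured compounds named here, no measured pair shows an aryl replaced by a benzyl on the amide-type nitrogen. Given that compound 3 already stands highest, a change of similar size is expected, more likely downward than upward, as a number 50 percentage points lower from compound 3 to compound 4 (beyond the scatter). Compound 4 is estimated at 145%, within a range from 85% to 205%.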

Compound 4, largest response reached (reported as efficacy), in percent of the reference or control that the assay uses: 179%
For compound 4 the middle estimate is 34 percentage points below the measured one; low and high end bracket the measured number.
By their numbers in this assay, from the lowest: compound 2; then compound 1; then compound 4; then compound 3.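

Among these compounds, exchanging 4-methoxyphenyl for benzyl on the amide-type nitrogen gives the first measured change at this position, a number 16 percentage points lower from compound 3 to compound 4 (beyond the scatter), so in this assay the response falls only modestly and stays high. Compound 4 also stands clear of both compounds that have an aryl group directly on the carbonyl carbon, with a number 74 percentage points higher from compound 2 to compound 4 (beyond the scatter) and a number 37 percentage points higher from compound 1 to compound 4 (beyond the scatter), and the two compounds with an amide-type nitrogen at that place hold the top two numbers of the four, with none going against this order. Nothing available gives a reason for the size of any of these steps.

The exchange removes the methoxy oxygen and alters how the ring is attached in a single step, so the measured change cannot be assigned to either alteration alone. From the compounds shown here alone, a plain phenyl or a 4-methoxybenzyl on this nitrogen would separate the two, and whether a longer chain such as 2-phenylethyl keeps the response this high remains open.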